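Methoxy for Bromo on a Weak Cytotoxic Scaffold

The source may report more compounds than this note shows. Statements on the series, on what has been measured and on what is new or still open speak of the compounds shown alone.

Compound 1 `COc1cc(C(=O)C2Sc3nnc(-c4cc(OC)c(OC)c(OC)c4)n3NC2c2ccco2)cc(OC)c1OC` and compound 2 `COc1cc(-c2nnc3n2NC(c2ccco2)C(C(=O)c2ccc(Br)cc2)S3)cc(OC)c1OC` share one core and differ only in the aryl group on the carbonyl carbon. In a functional assay on A549 cells (Homo sapiens) for cytotoxicity, read by MTT assay, with a stated time of 48 h (a lower number here means a stronger inhibitor, a higher number a weaker inhibitor), compound 1 gives 48300 nM and compound 2 gives 42100 nM; the step of a 1.1-fold lower number from compound 1 to compound 2 (0.06 log units; within the scatter) leaves compound 2 with the lower of the two numbers shown, a gap that is within the scatter. Compound 3 `COc1ccc(C(=O)C2Sc3nnc(-c4cc(OC)c(OC)c(OC)c4)n3NC2c2ccco2)cc1` carries the change (methoxy in place of bromo on an aromatic carbon). Because the larger earlier swap a 1.1-fold lower number from compound 1 to compound 2 (0.06 log units; within the scatter) stayed within the scatter, the expected step of a 1.1-fold higher number from compound 2 to compound 3 (0.03 log units; within the scatter) is also estimated to lie within it. Compound 3 is therefore estimated at 45000 nM, with a range from 20000 nM to 100000 nM.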

Compound 3, half-maximal inhibitory concentration: > 100000 nM
Compound 3 was reported as a limit; the forecaster's own chance of this, stated with the estimate: 10%; middle value at least 2.2-fold (0.34 log units) away from the limit.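

So the aromatic ring on the carbonyl is not indifferent to change in this assay: methoxy in place of bromo gives an at least 2.3-fold higher number from compound 2 to compound 3 (0.37 log units; beyond the scatter), and 4-methoxyphenyl in place of 3,4,5-trimethoxyphenyl gives an at least 2.0-fold higher number from compound 1 to compound 3 (0.31 log units; beyond the scatter), although the earlier swap of 4-bromophenyl for 3,4,5-trimethoxyphenyl stayed within the scatter. Both steps give only a minimum size, since compound 3 stands at a limit of the assay and not at a number: the limit of > 100000 nM in this assay, at which 1 of the 3 values shown sits.

On these data alone, how far past that limit compound 3 lies remains open. So does how an amine or a carboxylic acid at this place on the ring would read in this assay.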